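The compounds below may be only part of what the source reports. "The series", "measured", "known", "first", "only" and "open" are said of these compounds alone.

The measured compounds in this study:

Compound 1, `COC(=O)CNC1=CS(=O)(=O)O[C@@]12[C@@H](CO[Si](C)(C)C(C)(C)C)O[C@@H](n1cc(C)c(=O)n(C)c1=O)[C@@H]2O[Si](C)(C)C(C)(C)C`: 160000 nM
Compound 2, `COC(=O)NC1=CS(=O)(=O)O[C@@]12[C@@H](CO[Si](C)(C)C(C)(C)C)O[C@@H](n1cc(C)c(=O)n(C)c1=O)[C@@H]2O[Si](C)(C)C(C)(C)C`: > 200000 nM

Both were tested in a functional assay on HEL cells (Homo sapiens); on this read-out higher numbers stand for lower toxicity in this test and lower numbers for higher toxicity in this test. Compound 1 gives 160000 nM in this assay. For compound 2 the result of > 200000 nM is a limit of the assay and not a number. Among the compounds with values here, the single measured step, an at least 1.2-fold higher number from compound 1 to compound 2 (0.09 log units; that floor lies within the scatter), is thus bounded by the limit of > 200000 nM in this assay, at which 1 of the 2 values shown sits, and lies within the scatter.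

Compound 3, `Cc1cn([C@@H]2O[C@H](CO[Si](C)(C)C(C)(C)C)[C@@]3(OS(=O)(=O)C=C3NC(=O)c3ccccc3)[C@H]2O[Si](C)(C)C(C)(C)C)c(=O)n(C)c1=O`, has not yet been measured in this assay. It differs from compound 2 by phenyl in place of methoxy on a carbonyl carbon. Within the data shown here, no measured step concerns a phenyl in place of methoxy on a carbonyl carbon, so the only guide is that compound 2 sits at the limit and that the one change tried so far at the amine nitrogen left the read-out within scatter. Compound 3 is therefore estimated to stay near the limit, at 180000 nM, with a range from 60000 nM to 250000 nM. That estimate means an at least 1.1-fold lower number from compound 2 to compound 3 (0.04 log units; that floor lies within the scatter), which is expected to be no step beyond the scatter.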

Compound 3, half-maximal cytotoxic concentration: 9700 nM
The estimate for compound 3 lay 19-fold (1.27 log units) above the measured number; measured number below the stated range.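

In this assay, phenyl in place of methoxy on the carbonyl carbon gives an at least 20-fold lower number from compound 2 to compound 3 (1.31 log units; beyond the scatter). Benzoyl in place of (methoxycarbonyl)methyl on the amine nitrogen gives a 16-fold lower number from compound 1 to compound 3 (1.22 log units; beyond the scatter), so this position, where the one earlier step stayed within the scatter, can shift the read-out well beyond it, towards higher toxicity in this test. The step from compound 2 is only a floor, as the value of compound 2 is a limit of the assay: the limit of > 200000 nM in this assay, at which 1 of the 3 values shown sits.

As far as these compounds go, compound 3 alone carries an aromatic ring on that carbonyl carbon, so it remains open whether the ring is what counts, a question that a cyclohexyl, methyl or pyridyl group there would address. Also open, from the compounds shown here alone, is whether the change would read the same with free hydroxyl groups in place of the silyl ethers.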